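A Piperidinylmethyl Arm Added to Compound 1

The source may hold more compounds than are shown below. What is called first, only, known or untested is meant among the compounds shown, and "the series" means these compounds.

Measured in a functional assay on THP-1 cells (Homo sapiens) for inhibition, read by ELISA, with stated times of 30 min and 24 h, tested at 1 uM; a lower number here means a weaker effect, a higher number a stronger effect of the compound at the concentration tested:
compound 1, `COc1cc(O)c(C(=O)c2ccccc2F)c(OC)c1`, gives 11%
compound 2, `COc1cc(OC)c(C(=O)c2ccccc2Br)c(O)c1CN1CCCC1`, gives 19%
compound 3, `COc1cc(OC)c(C(=O)c2cccc(F)c2)c(O)c1CN1CCCC1`, gives 34%

Compound 1 stands lowest of the three numbers; compound 2 lies only within the scatter of it, whereas compound 3 lies beyond it. Among the compounds with values here, the only single-point step among the measured compounds is a number 15 percentage points higher from compound 2 to compound 3 (beyond the scatter), a swap of the aryl ring on the carbonyl carbon, and it does not touch the change considered here.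

Compound 4, `COc1cc(OC)c(C(=O)c2ccccc2F)c(O)c1CN1CCCCC1`, differs from compound 1 in one place: (piperidin-1-yl)methyl in place of hydrogen on an aromatic carbon. Within the data shown here, no measured pair isolates this addition. Compounds 2 and 3 each carry a comparable amine-bearing arm on the shared core, and both sit at or above compound 1, compound 2 giving 19% and compound 3 giving 34%; compound 2, with an ortho-halogenated aryl like compound 1, is the closer comparison and is within the scatter of compound 1. A modest rise is therefore expected, with the estimated step being a number 9 percentage points higher from compound 1 to compound 4 (within the scatter). Compound 4 is estimated at 20%, within a range from 5% to 40%.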

Compound 4, a percentage reported as activity, at one concentration (the size of the read-out at that concentration, not a potency): 18%
Compound 4: the middle estimate sits 2 percentage points above what was measured; the measured number falls inside the stated range.
By their numbers in this assay, from the lowest: compounds 1, 4 and 2 (each within the scatter of the next); then compound 3.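

In this assay, within the data shown here, this is the first pair that isolates the carbon ortho to a hydroxy group: placing (piperidin-1-yl)methyl there in place of hydrogen gives a number 7 percentage points higher from compound 1 to compound 4 (within the scatter) and so does not separate the two compounds at the single concentration tested. The earlier compounds shown here carried a comparable arm but offered no pair without one, so they could not show this. Nothing available here bears on why the addition reads this way.

The compounds shown leave open whether a morpholin-4-ylmethyl or dimethylaminomethyl arm, or a carboxylic acid, on this same carbon would read differently with the (2-fluorophenyl)carbonyl group kept in place. They also leave open whether the piperidinylmethyl arm would separate from hydrogen at any other concentration.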